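This account rests on a few compounds, and the source may have more. Where it says the series, first, only, none or still open, it means among the compounds named here.

Measured so far in this series:

Compound 1, `C=CCCCCCCCC#CC#CCO`: 3.23 ug/mL
Compound 2, `C=CCCCCCCCC#CC#CCOCC(=O)O`: 4.88 ug/mL

In a functional assay on SK-OV-3 cells (Homo sapiens) for cytotoxicity (on this read-out higher numbers stand for an effect only at larger amounts of compound and lower numbers for an effect already at smaller amounts), compound 2 gives 4.88 ug/mL, the higher of the two numbers measured, while compound 1 gives 3.23 ug/mL. Going by the values given here, the only step that connects them, a 1.5-fold higher number from compound 1 to compound 2 (0.18 log units; within the scatter), lies within the scatter, so the two compounds cannot be told apart on this read-out.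

Compound 3, `C=CCCCCCCCC#CC#CCOCC(=O)OC`, is the next compound and differs from compound 2 in one place: methyl in place of hydrogen on an oxygen next to a carbonyl group. Read one bond further out, the change is carboxy to methoxycarbonyl. Among the compounds with values here, no measured step covers this kind of change; the single step available, from hydroxy to carboxymethyl, was within the scatter, and it is the only guide. From that the expectation for compound 3 is a step of a 1.1-fold lower number from compound 2 to compound 3 (0.04 log units; within the scatter), which is to say no change beyond the scatter in this assay. Compound 3 is therefore estimated at 4.5 ug/mL, with a range from 2 ug/mL to 10 ug/mL, the width reflecting the absence of any measured step for this change.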

Compound 3, concentration for half-maximal effect: > 30 ug/mL
Compound 3: a limit, no number; the forecaster's own chance of this, stated with the estimate: 5%; at least 6.6-fold (0.82 log units) between middle value and limit.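

In this assay compound 3 gives > 30 ug/mL, which is a limit of the assay and not a number. Methyl in place of hydrogen on an oxygen next to a carbonyl group gives an at least 6.1-fold higher number from compound 2 to compound 3 (0.78 log units; beyond the scatter), and (methoxycarbonyl)methyl in place of hydrogen on the oxygen of compound 1 gives an at least 9.2-fold higher number from compound 1 to compound 3 (0.96 log units; beyond the scatter), whereas the earlier change to carboxymethyl stayed within the scatter, with a 1.5-fold higher number from compound 1 to compound 2 (0.18 log units; within the scatter). This part of the molecule is therefore not indifferent to change, since one added methyl turns a change that could not be told apart into one that can, though the size of both new steps has only a lower bound: the limit of > 30 ug/mL in this assay, at which 1 of the 3 values shown sits.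

The compounds shown leave open whether this rise in the number belongs to the methoxycarbonyl group alone or would also come with an ethyl ester or an amide in its place. They also leave open how a plain methyl ether on the oxygen of compound 1 would read, and where compound 3 itself would fall as an actual number.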